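Swapping Ethoxy for Chloro: A Step Into the Unmeasured

The source may report more compounds than this note shows. Statements on the series, on what has been measured and on what is new or still open speak of the compounds shown alone.

Values measured in a physicochemical assay, with a stated time of 30 min (a higher number here means a weaker inhibitor, a lower number a stronger inhibitor), so far:
Compound 1 `COc1cc2c(cc1OC)C(=O)C(C(=O)Nc1ccccc1)C2` gives 61.3 ug/mL
Compound 2 `COc1ccc(NC(=O)C2Cc3cc(OC)c(OC)cc3C2=O)cc1` gives 49.5 ug/mL
Compound 3 `CCOc1ccc(NC(=O)C2Cc3cc(OC)c(OC)cc3C2=O)cc1` gives 48.2 ug/mL

Compound 3 gives 48.2 ug/mL in this assay and cannot be separated from the other two compounds, since all three numbers lie within the usual scatter of repeat measurements. The next compound is compound 4 `COc1cc2c(cc1OC)C(=O)C(C(=O)Nc1ccc(Cl)cc1)C2`, which has chloro in place of ethoxy on an aromatic carbon. Among the compounds with values here, three measured steps bear on this change. Ethoxy in place of hydrogen gave (a 1.3-fold lower number from compound 1 to compound 3 (0.10 log units; within the scatter)), methoxy in place of hydrogen gave (a 1.2-fold lower number from compound 1 to compound 2 (0.09 log units; within the scatter)), and methyl added to the methoxy gave (a 1.0-fold lower number from compound 2 to compound 3 (0.01 log units; within the scatter)). All three steps are small, so this position has shown little response so far. Within the data shown here, no chloro compound has been measured, which leaves real uncertainty. Even so, no step beyond the scatter is expected in this assay, and the expected step is (a 1.0-fold higher number from compound 3 to compound 4 (0.02 log units; within the scatter)). The value of compound 4 is estimated at 50 ug/mL (expected range 28 ug/mL to 85 ug/mL).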

Compound 4, half-maximal inhibitory concentration: 56.8 ug/mL
Estimate against measurement, compound 4: 1.1-fold (0.06 log units) below; the range from low to high includes it.
By their numbers in this assay, from the lowest: compounds 3, 2, 4 and 1 (each within the scatter of the next).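

In this assay, this position on the aromatic ring, para to a large group, also shows little response to a group that carries no oxygen. Chloro is a single heavy atom with no hydrogen-bond acceptor, yet replacing ethoxy gives only a small step (a 1.2-fold higher number from compound 3 to compound 4 (0.07 log units; within the scatter)), and replacing methoxy does the same (a 1.1-fold higher number from compound 2 to compound 4 (0.06 log units; within the scatter)). Compared with plain hydrogen, the step is also small (a 1.1-fold lower number from compound 1 to compound 4 (0.03 log units; within the scatter)), and nothing measured here offers an explanation for such a flat result.

Going by these compounds, it remains open whether a group of a different kind at this place, such as an amine, a carboxylic acid or a chain longer than ethoxy, would produce a step beyond the scatter. On these data alone, the effect of chloro on the other carbons of this ring also remains open.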